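This account rests on a few compounds, and the source may have more. Where it says the series, first, only, none or still open, it means among the compounds named here.

Compound 1 `CCN(CC)CCNC(=O)c1ccc(C(CC)(CC)c2ccc(OCC(O)C(C)(C)C)c(C)c2)n1CC` gives 2500 nM
Compound 2 `C#CCNC(=O)c1ccc(C(CC)(CC)c2ccc(OCC(O)C(C)(C)C)c(C)c2)n1CC` gives 4400 nM
Compound 3 `CCn1c(C(=O)N(C)CCC#N)ccc1C(CC)(CC)c1ccc(OCC(O)C(C)(C)C)c(C)c1` gives 14900 nM

These numbers come from an ADME assay on L02 cells (Homo sapiens) for cytotoxicity, read by MTT assay, with a stated time of 48 h (a higher number here means a weaker inhibitor, a lower number a stronger inhibitor), and compound 3 holds the highest of the three. Compound 4 `CCn1c(C(=O)N(CCC#N)CCC#N)ccc1C(CC)(CC)c1ccc(OCC(O)C(C)(C)C)c(C)c1` has not yet been measured. Its difference from compound 3 is cyanomethyl in place of hydrogen on a saturated chain carbon bound to an amide-type nitrogen and in words this is cyanomethyl in place of hydrogen on a saturated chain carbon bound to an amide-type nitrogen, which also reads as methyl to 2-cyanoethyl.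

Within the data shown here, no measured step makes this exact change. The closest guides are the two steps that bring in the (2-cyanoethyl)(methyl)amino group on the carbonyl carbon. They are a 3.4-fold higher number from compound 2 to compound 3 (0.53 log units; beyond the scatter) and a 6.0-fold higher number from compound 1 to compound 3 (0.78 log units; beyond the scatter) and both are modest and upward. The remaining step, a 1.8-fold higher number from compound 1 to compound 2 (0.25 log units; within the scatter), lies within the scatter. A small further rise in this assay is therefore expected, probably no larger than the scatter. The estimate means a 1.3-fold higher number from compound 3 to compound 4 (0.13 log units; within the scatter) as the expected step. For compound 4 the estimated value is 20000 nM with an expected range from 8000 nM to 50000 nM in this assay.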

Compound 4, half-maximal inhibitory concentration: 1700 nM
Compound 4: middle estimate off by 12-fold (1.07 log units), on the high side, outside the stated range (below it).
By their numbers in this assay, from the lowest: compounds 4, 1 and 2 (each within the scatter of the next, the first and the last beyond it); then compound 3.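

In this assay, among these compounds, the earlier compounds could suggest that a nitrile-bearing chain on the amide raises the number, but cyanomethyl in place of hydrogen on a saturated chain carbon bound to an amide-type nitrogen gives an 8.8-fold lower number from compound 3 to compound 4 (0.94 log units; beyond the scatter) instead. The comparisons with the other two amides show a 2.6-fold lower number from compound 2 to compound 4 (0.41 log units; beyond the scatter) and a 1.5-fold lower number from compound 1 to compound 4 (0.17 log units; within the scatter), the second lying within the scatter, so the (2-(diethylamino)ethyl)amino group is not needed to reach this level. Nothing available explains why so small a change moves the number this far.

On these data alone, whether the nitrile itself matters stays open, since a plain propyl chain in place of 2-cyanoethyl would separate its effect from that of chain length. As far as these compounds go, how a 2-aminoethyl chain would read in this assay also remains unknown.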